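Benzyl ester in place of ethyl ester on the shared core

The source may hold more compounds than are shown below. What is called first, only, known or untested is meant among the compounds shown, and "the series" means these compounds.

For the measured compounds named here, compound 1 `CCOC(=O)c1c(-c2cccc(C(F)(F)F)c2)csc1N` sits lowest of the two numbers so far in an assay on isolated protein for inhibition of protein kinase C zeta type (Homo sapiens), with stated times of 1 h and 2.5 min, tested at 30 uM (a higher number here means more inhibition at the concentration tested (going by the name of the read-out), a lower number less inhibition), where compound 1 gives 30%. Its nearest neighbour is compound 2 `CCOC(=O)c1c(-c2cccc(C#N)c2)csc1N`, which in this assay gives 32%; the step of a number 2 percentage points higher from compound 1 to compound 2 (within the scatter) lies within the scatter. Compound 3 `Nc1scc(-c2cccc(C(F)(F)F)c2)c1C(=O)OCc1ccccc1` is not yet measured. It differs from compound 1 as follows: phenyl in place of methyl on a saturated chain carbon bound to an oxygen next to a carbonyl group. Going by the values given here, the only measured step, cyano in place of trifluoromethyl on an aromatic carbon, alters a different part of the molecule and was itself within the scatter, so it gives no guidance on changing the ester. Among the compounds with values here, no measured pair varies the ester group. With nothing to point either way, the expectation for compound 3 in this assay is a step of no change at the digits printed from compound 1 to compound 3 (within the scatter), i.e. none beyond the scatter. Compound 3 is therefore estimated at 30%, with a range from 12% to 50%.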

Compound 3, a percentage reported as inhibition, at one concentration (the size of the read-out at that concentration, not a potency): 29%
Estimate against measurement, compound 3: 1 percentage points above, and the stated range covers the measured number.
By their numbers in this assay, from the lowest: compounds 3, 1 and 2 (each within the scatter of the next).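

For the compounds shown here, the step of a number 1 percentage points lower from compound 1 to compound 3 (within the scatter) in this assay is the first reading at the ester position, where the earlier pair gave no information. Ethyl to benzyl brings in 6 heavy atoms and one six-membered aromatic ring of carbon only in place of a methyl, and the read-out does not separate the two compounds, so this position accepts that ring with no step beyond the scatter. No measurement shown here bears on why the number holds.

As far as these compounds go, whether a carboxylic acid or an amide at this position would read the same remains open, as does the effect of a longer chain such as phenethyl. Also open, from the compounds shown here alone, is whether the benzyl ester would read the same on the nitrile-bearing compound 2.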